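Notes on the step from chloro to methyl

A few compounds are considered here, and "the series" means these few. Any claim that something is new, unique, unknown or untested is made for them only; others in the source may bear on it.

compound 1 `COc1ccc(NC(=O)[C@H]2CN(C)C[C@@H]2c2ccc(/C=C/C(=O)Nc3ccccc3N)cc2)cc1`: 54 mL/min/kg
compound 2 `CN1C[C@H](C(=O)Nc2ccc(F)c(Cl)c2)[C@@H](c2ccc(/C=C/C(=O)Nc3ccccc3N)cc2)C1`: 34 mL/min/kg

In an in vitro ADME assay on microsomes from liver (Mus musculus) for pharmacokinetics, read by LC-MS, with a stated time of 10 min, tested at 1 uM (on this read-out higher numbers stand for fast clearance and lower numbers for slow clearance), compound 2 gives 34 mL/min/kg and sits within the scatter of compound 1. Compound 3 `Cc1cc(NC(=O)[C@H]2CN(C)C[C@@H]2c2ccc(/C=C/C(=O)Nc3ccccc3N)cc2)ccc1F` differs from compound 2 by methyl in place of chloro on an aromatic carbon as methyl in place of chloro on an aromatic carbon, ortho to a fluoro group. Within the data shown here, with a 1.6-fold lower number from compound 1 to compound 2 (0.20 log units; within the scatter) as the one measured step bearing on this swap, no step beyond the scatter is expected in this assay here. The expected change is a 1.3-fold higher number from compound 2 to compound 3 (0.12 log units; within the scatter) and stays an estimate. For compound 3 the estimated clearance is 45 mL/min/kg with a range of 22 mL/min/kg to 85 mL/min/kg on this read-out.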

Compound 3, clearance: 62 mL/min/kg
Beside the measured number, compound 3's estimate is 1.4-fold (0.14 log units) below it; the measured number falls inside the stated range.
By their numbers in this assay, from the lowest: compounds 2, 1 and 3 (each within the scatter of the next).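

In this assay, methyl in place of chloro on this aromatic carbon, ortho to a fluoro group, reads as a 1.8-fold higher number from compound 2 to compound 3 (0.26 log units; within the scatter), so neither group separates from the other at this position. Taking 4-fluoro-3-methylphenyl in place of 4-methoxyphenyl on the amide nitrogen gives a 1.1-fold higher number from compound 1 to compound 3 (0.06 log units; within the scatter), and all three aryl groups remain within the scatter of one another.

Going by these compounds, whether an amine or a carboxylic acid on this carbon would give a step beyond the scatter stays open. The reason for these numbers also stays open, since no measurement shown bears on it.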